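The source may report more compounds than this note shows. Statements on the series, on what has been measured and on what is new or still open speak of the compounds shown alone.

Measured so far in a functional assay on MCF7 cells (Homo sapiens) for cytotoxicity, read by MTT assay, with a stated time of 4 days; a lower number here means a stronger inhibitor, a higher number a weaker inhibitor:
compound 1 `Cc1ccc(S(=O)(=O)Oc2ccc3c(c2C)[C@H](Cn2cc(-c4ccc(F)cc4)nn2)[C@@]24CC(=O)[C@@](C)(CC[C@@H]32)C4)cc1`: > 20000 nM
compound 2 `Cc1ccc(S(=O)(=O)Oc2ccc3c(c2C)[C@H](Cn2cc(-c4ccc(Cl)cc4)nn2)[C@@]24CC(=O)[C@@](C)(CC[C@@H]32)C4)cc1`: > 20000 nM

In this assay compound 1 reaches only the limit given as > 20000 nM. Compound 2 likewise reaches only the limit given as > 20000 nM. Both values therefore sit at the same boundary, and the step that the two limits leave unreadable from compound 1 to compound 2 cannot be read as a number; the limit of > 20000 nM in this assay, at which 2 of the 2 values shown sit, describes where every shown value sits. Where compound 2 stands is thus known only as a limit, not as a measured concentration.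

Compound 3 `Cc1ccc(S(=O)(=O)Oc2ccc3c(c2C)[C@H](Cn2cc(-c4ccccn4)nn2)[C@@]24CC(=O)[C@@](C)(CC[C@@H]32)C4)cc1` is not yet measured. It differs from compound 2 by pyridin-2-yl in place of 4-chlorophenyl on an aromatic carbon. Going by the values given here, no measured step bears directly on this change: the only step in hand, a step that the two limits leave unreadable from compound 1 to compound 2, runs between two limits and gives no readable size. With both known values at the limit, no basis exists to expect a step beyond the scatter in either direction. The step expected is a number no higher from compound 2 to compound 3 (the limit leaves the size open). Compound 3 is therefore estimated at 20000 nM, in a range from 8000 nM to 60000 nM, with a real chance that this assay again returns only a limit.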

Compound 3, half-maximal inhibitory concentration: > 20000 nM
Compound 3 ended at the assay's limit (the forecaster's own chance of this, stated with the estimate: 70%); the middle value sits exactly at the limit.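

In this assay compound 3 gives > 20000 nM, which is a limit and not a number. The steps joining compound 3 to compound 1 and to compound 2 therefore cannot be read, and all three compounds share one boundary: the limit of > 20000 nM in this assay, at which 3 of the 3 values shown sit. The compounds shown leave open how compound 1, compound 2 and compound 3 compare in this assay.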